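The source may hold more compounds than are shown below. What is called first, only, known or untested is meant among the compounds shown, and "the series" means these compounds.

Of the compounds shown here, three sharing one core have so far been measured in an ADME assay on J774 cells (Mus musculus) for cytotoxicity, read by MTT assay, with a stated time of 48 h, tested at 100 ug/mL; a lower number here means a stronger effect, a higher number a weaker effect of the compound at the concentration tested. Compound 1 `O=C(N/N=C/c1ccc(Br)cc1)c1cnccn1` gives 100%, level with compound 3 `O=C(N/N=C/c1cccc(O)c1)c1cnccn1`, which gives 100%; the gap between them lies within the scatter, and together they hold the highest of the three numbers. Compound 2 `O=C(N/N=C/c1ccccc1O)c1cnccn1` gives 0.3%, far beneath compound 1 and well beyond the scatter. The next compound, compound 4 `O=C(N/N=C/c1ccc(O)cc1)c1cnccn1`, differs from compound 1 in a single place: hydroxy in place of bromo on an aromatic carbon. Within the data shown here, no two measured compounds differ in only one place, so no measured step exists to lean on. Since compound 3 carries a hydroxy and gives 100%, while compound 2 carries one and gives 0.3%, the pattern is mixed. The step of a number 5 percentage points lower from compound 1 to compound 4 (within the scatter) is expected to stay small, within the scatter. Compound 4 is expected to give 95%, within a range from 65% to 100%.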

Compound 4, a percentage reported as activity, at one concentration (the size of the read-out at that concentration, not a potency): 81%
Compound 4: middle estimate off by 14 percentage points, on the high side; the measured number falls inside the stated range.
By their numbers in this assay, from the lowest: compound 2; then compound 4; then compounds 1 and 3 (each within the scatter of the next).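

Among these compounds, this is the first measured step at a single place: on an aromatic carbon para to a large group, hydroxy in place of bromo gives a number 19 percentage points lower from compound 1 to compound 4 (beyond the scatter) in this assay. The number at this position therefore responds to the group placed there, though the step is modest. Nothing at hand gives a reason for this step. As far as these compounds go, whether an amine or a carboxylic acid on the same carbon would move the number further stays open. So does whether a methoxy would behave like the hydroxy.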